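The source may report more compounds than this note shows. Statements on the series, on what has been measured and on what is new or still open speak of the compounds shown alone.

Working notes on the series. In a functional assay on MDA-MB-231 cells (Homo sapiens) for inhibition, read by MTT assay, with a stated time of 48 h (a lower number here means a stronger inhibitor of growth, a higher number a weaker inhibitor of growth), compound 1 (`S=C(Nc1ccccc1)Nc1ccc2ncnc(Nc3cccc(Br)c3)c2c1`) stands at 10000 nM and compound 2 (`FC(F)(F)c1ccc(NC(=S)Nc2ccc3ncnc(Nc4cccc(Br)c4)c3c2)cc1`) at 12200 nM while compound 3 (`S=C(Nc1cc(Cl)cc(Cl)c1)Nc1ccc2ncnc(Nc3cccc(Br)c3)c2c1`) at 3000 nM gives the lowest of the three numbers. The next change leads to compound 4 (`S=C(NCc1ccc(Cl)cc1)Nc1ccc2ncnc(Nc3cccc(Br)c3)c2c1`), with 4-chlorobenzyl in place of 3,5-dichlorophenyl on an amide-type nitrogen. Three measured steps at this nitrogen bear on it. Replacing phenyl with 3,5-dichlorophenyl gave a modest step (a 3.3-fold lower number from compound 1 to compound 3 (0.52 log units; beyond the scatter)), and replacing 4-(trifluoromethyl)phenyl with it gave another (a 4.1-fold lower number from compound 2 to compound 3 (0.61 log units; beyond the scatter)). The trifluoromethyl step stayed within the scatter (a 1.2-fold higher number from compound 1 to compound 2 (0.09 log units; within the scatter)). Among the compounds with values here, no measured compound carries a benzyl group, so the read-across is loose. Compound 4 loses the 3,5-dichlorophenyl group of compound 3, and the numbers of compound 1 (10000 nM) and compound 2 (12200 nM) suggest a return toward their level. A modest step toward a higher number is therefore expected (a 2.7-fold higher number from compound 3 to compound 4 (0.43 log units; beyond the scatter)). Compound 4 is expected at 8000 nM (estimated range 3000 nM to 20000 nM).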

Compound 4, concentration for 50% growth inhibition: 23000 nM
For compound 4 the middle estimate is 2.9-fold (0.46 log units) below the measured one; the measured number lies above the stated range.
By their numbers in this assay, from the lowest: compound 3; then compounds 1, 2 and 4 (each within the scatter of the next, the first and the last beyond it).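

In this assay, 4-chlorobenzyl on the amide-type nitrogen gives up the whole advantage held by 3,5-dichlorophenyl (a 7.7-fold higher number from compound 3 to compound 4 (0.88 log units; beyond the scatter)). The result also goes past the level of the unsubstituted phenyl compound (a 2.3-fold higher number from compound 1 to compound 4 (0.36 log units; beyond the scatter)), while the gap to the 4-(trifluoromethyl)phenyl compound stays within the scatter (a 1.9-fold higher number from compound 2 to compound 4 (0.28 log units; within the scatter)). This position therefore tolerates changes of group with little shift among compounds 1, 2 and 4, and only compound 3 stands apart from all the others. Nothing measured here accounts for these steps.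

The compounds shown leave open whether the loss follows the extra carbon of the benzyl group or the change in chlorine substitution, a question that 3,5-dichlorobenzyl or 4-chlorophenyl on this nitrogen would address. From the compounds shown here alone, how a longer chain such as 2-phenylethyl would read at this nitrogen also remains open.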